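The compounds below may be only part of what the source reports. "The series", "measured", "known", "first", "only" and "open" are said of these compounds alone.

compound 1 `COc1cc(OC)c(Cl)c(-c2ccc3c(NC(=O)c4ccc(C5CCN(C)CC5)cc4)n[nH]c3n2)c1Cl` gives 8.2 nM
compound 2 `C=CCN1CCN(c2ccc(C(=O)Nc3n[nH]c4nc(-c5c(Cl)c(OC)cc(OC)c5Cl)ccc34)cc2)CC1` gives 3.3 nM
compound 3 `COc1cc(OC)c(Cl)c(-c2ccc3c(NC(=O)c4ccccc4)n[nH]c3n2)c1Cl` gives > 1000 nM as a limit of the assay

Compound 3 gives only a limit in a functional assay on NCI-H1581 cells (Homo sapiens) for antiproliferative activity, read by CCK-8 assay, with a stated time of 72 h (a higher number here means a weaker inhibitor, a lower number a stronger inhibitor), and no number. Compound 4 `COc1cc(OC)c(Cl)c(-c2ccc3c(NC(=O)c4ccc(N5CCNCC5)cc4)n[nH]c3n2)c1Cl` differs from it by piperazin-1-yl in place of hydrogen on an aromatic carbon and has piperazin-1-yl in place of hydrogen on an aromatic carbon, para to a large group. Among the measured compounds shown here, two measured steps bear on this when read in reverse: an at least 120-fold higher number from compound 1 to compound 3 (2.08 log units; beyond the scatter) and an at least 300-fold higher number from compound 2 to compound 3 (2.48 log units; beyond the scatter) are both large, each losing a ring group at that place. Between those two ring groups, a 2.5-fold lower number from compound 1 to compound 2 (0.40 log units; beyond the scatter) is only modest. An expected step of an at least 120-fold lower number from compound 3 to compound 4 (2.09 log units; beyond the scatter) follows, large and toward a lower number. For compound 4 the estimate is 8 nM with 2 nM to 40 nM as the expected span.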

Compound 4, half-maximal inhibitory concentration: 1.4 nM
Beside the measured number, compound 4's estimate is 5.7-fold (0.76 log units) above it, outside the stated range (below it).
By their numbers in this assay, from the lowest: compound 4; then compound 2; then compound 1. At a limit, above all of these: compound 3.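

In this assay, a ring amine whose nitrogen carries only hydrogen also works at this place: piperazin-1-yl gives an at least 710-fold lower number from compound 3 to compound 4 (2.85 log units; beyond the scatter). Compound 3 stands only at a limit of the assay: the limit of > 1000 nM in this assay, at which 1 of the 4 values shown sits. Hydrogen in place of allyl on that nitrogen gives a 2.4-fold lower number from compound 2 to compound 4 (0.37 log units; beyond the scatter), and piperazin-1-yl in place of 1-methylpiperidin-4-yl gives a 5.9-fold lower number from compound 1 to compound 4 (0.77 log units; beyond the scatter), both modest, so the allyl group is not required for a low number.

The compounds shown leave open whether morpholine, with oxygen in place of that nitrogen, would keep the number low. They also leave open whether an open-chain amine such as dimethylamino would serve without a ring.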